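The source may report more compounds than this note shows. Statements on the series, on what has been measured and on what is new or still open speak of the compounds shown alone.

Three compounds built on one shared core were tested in an assay on cells for inhibition of sodium/hydrogen exchanger (Oryctolagus cuniculus); on this read-out higher numbers stand for weaker inhibition and lower numbers for stronger inhibition. Compound 1 `Cc1cc2c(cc1C(=O)N=C(N)N)S(=O)(=O)CC2(C)O` gives 30 nM. Compound 2 `Cc1cc2c(cc1C(=O)N=C(N)N)S(=O)(=O)CC2C` gives 44 nM. Compound 3 `Cc1cc2c(cc1C(=O)N=C(N)N)S(=O)(=O)CC2O` gives 70 nM. Compound 2 differs from compound 1 by hydrogen in place of hydroxy on a saturated ring carbon and the step was a 1.5-fold higher number from compound 1 to compound 2 (0.17 log units; within the scatter). Compound 3 differs from compound 1 by hydrogen in place of methyl on a saturated ring carbon and the step was a 2.3-fold higher number from compound 1 to compound 3 (0.37 log units; beyond the scatter). Between compounds 2 and 3 the step was a 1.6-fold higher number from compound 2 to compound 3 (0.20 log units; within the scatter).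

Compound 4 `Cc1cc2c(cc1C(=O)N=C(N)N)S(=O)(=O)CC2` has not yet been measured. It differs from compound 3 by hydrogen in place of hydroxy on a saturated ring carbon. This is the same change as that from compound 1 to compound 2, made at the same place, the two cores differing only in the methyl just described. The step from compound 3 to compound 4 in this assay is expected to be about as small as the earlier one, because that step was a 1.5-fold higher number from compound 1 to compound 2 (0.17 log units; within the scatter); the expectation is a 1.4-fold higher number from compound 3 to compound 4 (0.15 log units; within the scatter). Compound 4 is therefore estimated to give 100 nM, most likely between 50 nM and 220 nM.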

Compound 4, half-maximal inhibitory concentration: 60 nM
Estimate against measurement, compound 4: 1.7-fold (0.22 log units) above; the measured number falls inside the stated range.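

In this assay, hydrogen in place of hydroxy on a saturated ring carbon gave a 1.2-fold lower number from compound 3 to compound 4 (0.07 log units; within the scatter), and this step agrees with the earlier one on the methyl-bearing core: the same change on two cores in this assay, a 1.5-fold higher number (0.17 log units; within the scatter) from compound 1 to compound 2 and a 1.2-fold lower number (0.07 log units; within the scatter) from compound 3 to compound 4, 1.7-fold (0.23 log units) apart, within the scatter of two such steps. Hydrogen in place of methyl gave a 1.4-fold higher number from compound 2 to compound 4 (0.13 log units; within the scatter) on the core without hydroxy, and this step likewise agrees with its earlier counterpart on the hydroxy-bearing core: the same change on two cores in this assay, a 2.3-fold higher number (0.37 log units; beyond the scatter) from compound 1 to compound 3 and a 1.4-fold higher number (0.13 log units; within the scatter) from compound 2 to compound 4, 1.7-fold (0.23 log units) apart, within the scatter of two such steps. Among these compounds, each change therefore carried across these two cores without a difference beyond the scatter, but this rests on only two pairs per change. Three of the four steps lie within the scatter. The data do not fix a direction or size for either change or show that it would carry to any other core.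

The compounds shown leave open how an amine, a carboxylic acid or a longer chain on that saturated ring carbon would read. They also leave open whether either step would hold with a different group in place of the methyl on the aromatic ring.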